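Trifluoromethyl for bromo on a tobacco inhibitor

The source may hold more compounds than are shown below. What is called first, only, known or untested is meant among the compounds shown, and "the series" means these compounds.

compound 1 `Cc1nc(Nc2ccc(Br)cc2)c2cc[nH]c2n1`: 170000000 nM
compound 2 `CC(=O)c1ccc(Nc2[nH]c(C)nc3nccc2-3)cc1`: 646000000 nM

In a functional assay on the whole organism for inhibition, with Nicotiana tabacum as the target (on this read-out higher numbers stand for weaker inhibition and lower numbers for stronger inhibition), compound 1 gives 170000000 nM, the lowest of the two numbers shown. Compound 2 gives 646000000 nM, a gap beyond the scatter. Compound 3 `Cc1nc(Nc2ccc(C(F)(F)F)cc2)c2cc[nH]c2n1` differs from compound 1 by trifluoromethyl in place of bromo on an aromatic carbon, on an aromatic carbon of a six-membered aromatic ring of carbon only, para to a large group. Within the data shown here, no measured pair shows this change, so the expected step from bromo to trifluoromethyl is none beyond the scatter, with the estimated step being a 1.1-fold lower number from compound 1 to compound 3 (0.03 log units; within the scatter). Compound 3 is therefore expected at 160000000 nM, within a range from 50000000 nM to 500000000 nM.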

Compound 3, half-maximal inhibitory concentration: 70800000 nM
Compound 3: middle estimate off by 2.3-fold (0.35 log units), on the high side; measured number inside the range.
By their numbers in this assay, from the lowest: compound 3; then compound 1; then compound 2.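

In this assay, swapping bromo for trifluoromethyl on the aromatic carbon para to a large group gives the first step read in one place, a 2.4-fold lower number from compound 1 to compound 3 (0.38 log units; beyond the scatter). The earlier compounds shown here offered no such pair, and this one shows that the number at this position responds to the change, if only modestly. Nothing available accounts for the size of this step. The compounds shown leave open how a nitrile, a methoxy group or an amine at this position would compare. They also leave open whether the step holds on another core.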